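The source may report more compounds than this note shows. Statements on the series, on what has been measured and on what is new or still open speak of the compounds shown alone.

Compound 1 `COc1ccc(-c2ccccc2C#N)c(OC)c1OC`: 50000 nM
Compound 2 `COc1ccc(C2CC=CCC2C#N)c(OC)c1OC`: > 100000 nM

Among the compounds with values here, in an assay for inhibition of tubulin polymerization-promoting protein (Bos taurus) (a lower number here means that less compound is needed, a higher number that more compound is needed for the effect), compound 1 gives 50000 nM, the only number in the set. For compound 2 the result is a limit of the assay, > 100000 nM, (the limit of > 100000 nM in this assay, at which 1 of the 2 values shown sits). Compound 3 `COc1ccc(-c2ccc(OC)c(OC)c2OC)c(C#N)c1` is the next analogue of compound 1; the change is methoxy in place of hydrogen on an aromatic carbon. Within the data shown here, no step between two measured compounds is known, so the size of the step in this assay is not set by earlier data; no change beyond the scatter is expected. Compound 3 is estimated at 50000 nM, with a range of 15000 nM to 150000 nM. The expected step is no change at the digits printed from compound 1 to compound 3 (within the scatter), within the scatter.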

Compound 3, half-maximal effective concentration: 6250 nM
The estimate for compound 3 lay 8.0-fold (0.90 log units) above the measured number, outside the stated range (below it).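

In this assay, methoxy in place of hydrogen on an aromatic carbon, meta to a cyano group and para to a large group, gives an 8.0-fold lower number from compound 1 to compound 3 (0.90 log units; beyond the scatter). Within the data shown here, this is the first step that can be read, and it shows that this position is not silent: one added group here moves the number beyond the scatter. Nothing at hand accounts for the size of the step. From the compounds shown here alone, with one group at this position, it stays open whether hydroxyl, fluorine or a longer chain such as ethoxy would give a similar step.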